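The source may report more compounds than this note shows. Statements on the series, on what has been measured and on what is new or still open speak of the compounds shown alone.

Measured compounds:
- compound 1 `CC(C)N1CCN(Cc2csc(N)c2C(=O)c2ccc(Cl)cc2)CC1`: 7.3% in a functional assay on CHO cells with adenosine receptor A1 (Homo sapiens) as the target, read by cAMP accumulation and immunoassay, with a stated time of 6 min, tested at 1 uM; on this read-out higher numbers stand for a weaker effect at the one concentration tested and lower numbers for a stronger effect
- compound 2 `Nc1scc(CN2CCN(c3cccc(Cl)c3Cl)CC2)c1C(=O)c1ccc(Cl)cc1`: -57% in this assay
- compound 3 `Nc1scc(CN2CCN(c3ccc(Cl)c(C(F)(F)F)c3)CC2)c1C(=O)c1ccc(Cl)cc1`: -47% in this assay

Compound 2 has the lowest number of the three. Its nearest neighbour is compound 3, a number 10 percentage points higher from compound 2 to compound 3 (within the scatter), while compound 1 lies far from it, a number 64.3 percentage points lower from compound 1 to compound 2 (beyond the scatter). Compound 4 `Nc1scc(CN2CCN(c3ccncc3)CC2)c1C(=O)c1ccc(Cl)cc1` is not yet measured; it differs from compound 2 in one place: pyridin-4-yl in place of 2,3-dichlorophenyl on an amine nitrogen in a ring.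

Among the measured compounds shown here, no measured step replaces one aromatic group on that ring nitrogen by another bearing a nitrogen atom, so the bearing steps are indirect. Both steps from compound 1, a number 64.3 percentage points lower from compound 1 to compound 2 (beyond the scatter) and a number 54.3 percentage points lower from compound 1 to compound 3 (beyond the scatter), were large, showing that an aromatic group on that nitrogen in place of isopropyl gives a much lower number. The step between the two aromatic groups, a number 10 percentage points higher from compound 2 to compound 3 (within the scatter), was within the scatter. The new group keeps the aromatic ring but drops both chlorine atoms, so an intermediate number is expected: compound 4 is estimated at -25%, with a range from -60% to 10%, meaning an expected step of a number 32 percentage points higher from compound 2 to compound 4 (beyond the scatter).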

Compound 4, a percentage reported as activity, at one concentration (the size of the read-out at that concentration, not a potency): -8.3%
Compound 4: middle estimate off by 16.7 percentage points, on the low side; low and high end bracket the measured number.
By their numbers in this assay, from the lowest: compounds 2 and 3 (each within the scatter of the next); then compound 4; then compound 1.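

In this assay, an aromatic ring on the amine nitrogen in the ring does not by itself bring the large drop seen with compounds 2 and 3: a number 15.6 percentage points lower from compound 1 to compound 4 (beyond the scatter) is only a modest step. The pyridin-4-yl group sits well above both substituted phenyl groups, with a number 48.7 percentage points higher from compound 2 to compound 4 (beyond the scatter) and a number 38.7 percentage points higher from compound 3 to compound 4 (beyond the scatter). The number at this position therefore depends on the kind of aromatic group and not merely on its presence, and no supporting measurement explains the difference.

The change to pyridin-4-yl both adds a ring nitrogen and removes the chlorines, so the two changes cannot be separated here. Unsubstituted phenyl would divide them, while 4-chlorophenyl and pyridin-3-yl would test the roles of a single chlorine and of the ring nitrogen's placement.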